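This account rests on a few compounds, and the source may have more. Where it says the series, first, only, none or still open, it means among the compounds named here.

In a functional assay on MCF7 cells (Homo sapiens) for inhibition, read by fluorescence, with a stated time of 72 h (a lower number here means a stronger inhibitor, a higher number a weaker inhibitor), compound 1 `CCn1cnc2c(NC(=N)N)nc(N)nc21` gives 54300 nM, while compound 2 `CC[C@@H](CO)Nc1nc(NC(=N)N)c2ncn(C(C)C)c2n1` gives 1600 nM. Compound 2 therefore holds the lower of the two numbers, and the gap between them lies beyond the scatter. Compound 3 `CC(C)n1cnc2c(NC(=N)N)nc(N3CCC[C@H]3CO)nc21` carries 2-(hydroxymethyl)pyrrolidin-1-yl in place of the (1-(hydroxymethyl)propyl)amino of compound 2, on an aromatic carbon between two ring nitrogen atoms: 2-(hydroxymethyl)pyrrolidin-1-yl in place of (1-(hydroxymethyl)propyl)amino on an aromatic carbon. Among the measured compounds shown here, no measured pair shows this change on its own, so the expectation starts only from the value of compound 2 and the structural change. A modest move in this assay towards a higher number, meaning a somewhat weaker inhibitor, is expected, and it may not clear the scatter by much. The expected size is a 1.9-fold higher number from compound 2 to compound 3 (0.27 log units; within the scatter). For compound 3 the estimated value is 3000 nM, with an expected range from 1000 nM to 10000 nM.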

Compound 3, half-maximal inhibitory concentration: 6200 nM
Compound 3: the middle estimate sits 2.1-fold (0.32 log units) below what was measured; the measured number falls inside the stated range.
By their numbers in this assay, from the lowest: compound 2; then compound 3; then compound 1.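

Replacing (1-(hydroxymethyl)propyl)amino with 2-(hydroxymethyl)pyrrolidin-1-yl on this aromatic carbon between two ring nitrogen atoms gives, in this assay, a 3.9-fold higher number from compound 2 to compound 3 (0.59 log units; beyond the scatter), so the position does respond to the group it carries, and the response is a weakening. The change has two sides: the open chain gives way to a five-membered non-aromatic ring, and the count of hydrogen-bond donors falls from 2 to 1, so this single step cannot separate the two. No measurement on hand accounts for the step.

Which of these two differences carries the step stays open, as does the part played by the hydroxymethyl. As far as these compounds go, how a plain pyrrolidin-1-yl, a piperidin-1-yl or a simple propylamino chain without the hydroxyl would read at this position also remains unknown.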